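Swapping chloro for fluoro on compound 2

The source may report more compounds than this note shows. Statements on the series, on what has been measured and on what is new or still open speak of the compounds shown alone.

Compound 1 `COc1cccc(CSc2nnc([C@@H](C)c3ccc4cc(OC)ccc4c3)n2-c2ccc(Cl)cc2)c1`: <= 400000 nM (a limit)
Compound 2 `COc1ccc2cc([C@H](C)c3nnc(SCc4ccc(Cl)cc4)n3-c3ccc(Cl)cc3)ccc2c1`: 109000 nM

Within the data shown here, in a functional assay on DU-145 cells (Homo sapiens) for cytotoxicity, read by MTT assay (on this read-out higher numbers stand for weaker inhibition and lower numbers for stronger inhibition), compound 2 gives 109000 nM, the only true number so far. Compound 1 gives <= 400000 nM, which is a limit and not a number. Among the measured compounds shown here, the single measured step, a step that the limit leaves unreadable from compound 1 to compound 2, therefore has no readable size, as the limit of <= 400000 nM in this assay, at which 1 of the 2 values shown sits, shows. Compound 3 `COc1ccc2cc([C@H](C)c3nnc(SCc4ccc(F)cc4)n3-c3ccc(Cl)cc3)ccc2c1` differs from compound 2 by fluoro in place of chloro on an aromatic carbon. For the measured compounds named here, no measured step covers this swap, so no shift beyond the scatter is expected in this assay. The expected change is a 1.1-fold lower number from compound 2 to compound 3 (0.04 log units; within the scatter). Compound 3 is estimated at 100000 nM, within an expected range of 40000 nM to 250000 nM.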

Compound 3, half-maximal inhibitory concentration: 33600 nM
Beside the measured number, compound 3's estimate is 3.0-fold (0.47 log units) above it; measured number outside the range, below it.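

In this assay, the halogen on this benzyl ring matters: fluoro in place of chloro gives a 3.2-fold lower number from compound 2 to compound 3 (0.51 log units; beyond the scatter). Among these compounds, this is the first readable size of any change, and it shows that swapping a single halogen at this place can yield stronger inhibition. The steps starting from compound 1 cannot be read: the limit of <= 400000 nM in this assay, at which 1 of the 3 values shown sits.

The compounds shown leave open what plain hydrogen, a methyl group or a trifluoromethyl group would do at this place. They also do not show whether bromo would continue the change seen from chloro to fluoro.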